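A few compounds are considered here, and "the series" means these few. Any claim that something is new, unique, unknown or untested is made for them only; others in the source may bear on it.

Measured in a physicochemical assay for solubility; on this read-out higher numbers stand for higher solubility and lower numbers for lower solubility:

Compound 1 `CC(C)(C)OC(=O)NCc1ccccc1NC(=O)c1cnc2ccccc2c1`: 15 ug/mL
Compound 2 `NC(=O)c1ccccc1NC(=O)c1cnc2ccccc2c1`: 5 ug/mL
Compound 3 `CC(C)(C)OC(=O)NCc1ccccc1NC(=O)c1cc2cc([N+](=O)[O-])ccc2s1`: < 5 ug/mL, which is a limit of this assay and not a number.

Compound 1 and compound 2 share a core and differ in one place: carbamoyl in place of ((tert-butoxycarbonyl)amino)methyl on an aromatic carbon. This change gave a 3.0-fold lower number from compound 1 to compound 2 (0.48 log units; beyond the scatter). Compound 3 is built on a different core; the difference between the two cores is not broken down here. Compound 4 `NC(=O)c1ccccc1NC(=O)c1cc2cc([N+](=O)[O-])ccc2s1` has not yet been measured. It stands to compound 3 as compound 2 stands to compound 1: carbamoyl in place of ((tert-butoxycarbonyl)amino)methyl on an aromatic carbon. The place is the same in both pairs, so this is the same change.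

For compound 3 to compound 4 a step of about the same size is expected, a step that the limit leaves unreadable from compound 3 to compound 4, because the limit of < 5 ug/mL in this assay, at which 1 of the 3 values shown sits, already holds compound 3, so any lower number would again fall under that limit. In this assay compound 4 is expected to give about 2 ug/mL, with a plausible range from 0.5 ug/mL to 5 ug/mL, and the assay is most likely to report only a limit for it.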

Compound 4, solubility: 10 ug/mL
Beside the measured number, compound 4's estimate is 5.0-fold (0.70 log units) below it, outside the stated range (above it).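

In this assay, the same change, carbamoyl in place of ((tert-butoxycarbonyl)amino)methyl on an aromatic carbon, gave a 3.0-fold lower number from compound 1 to compound 2 (0.48 log units; beyond the scatter) on the first core, but an at least 2.0-fold higher number from compound 3 to compound 4 (0.30 log units; that floor lies within the scatter) on the second. Compound 3 gives < 5 ug/mL, which is a limit of the assay and not a number. The fall seen on the first core therefore did not carry over to the second, where compound 4 does not read lower than compound 3, but the pair does not show the true size of the rise, nor that the rise is firmly beyond the scatter.

Among these compounds, with only two cores and two groups in this place, it remains open which way this change would go on a third core. As far as these compounds go, it also remains open how an amine, a carboxylic acid or a longer chain in the same place would read in this assay on either core.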